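This account rests on a few compounds, and the source may have more. Where it says the series, first, only, none or still open, it means among the compounds named here.

Compound 1 `CCCNC(=O)c1ccc(Oc2nc(-c3c(C)noc3C)cnc2N)cc1`: 47800 nM
Compound 2 `Cc1noc(C)c1-c1cnc(N)c(Oc2ccc(C(=O)NC3CC3)cc2)n1`: 43300 nM
Compound 3 `Cc1noc(C)c1-c1cnc(N)c(Oc2ccc(C(=O)Nc3ccccc3Cl)cc2)n1`: 60500 nM

In a functional assay on U-87MG ATCC cells for inhibition, with U-87 MG (Homo sapiens) as the target, read by MTT assay, with a stated time of 72 h (on this read-out lower numbers stand for stronger inhibition and higher numbers for weaker inhibition), compound 3 gives the highest of the three numbers, yet a 1.3-fold higher number from compound 1 to compound 3 (0.10 log units; within the scatter) and a 1.4-fold higher number from compound 2 to compound 3 (0.15 log units; within the scatter), so all three compounds sit within the scatter of one another. Compound 4 `Cc1noc(C)c1-c1cnc(N)c(Oc2ccc(C(=O)Nc3cccc(Cl)n3)cc2)n1` differs from compound 3 in one place: 6-chloropyridin-2-yl in place of 2-chlorophenyl on an amide-type nitrogen. Every measured step swaps the group on this same amide-type nitrogen, and none of them moved the number beyond the scatter; besides the two steps into compound 3, a 1.1-fold lower number from compound 1 to compound 2 (0.04 log units; within the scatter). Within the data shown here, no measured step exchanges one aromatic ring for another, so the new change is only loosely covered. On that basis the estimated step is a 1.0-fold lower number from compound 3 to compound 4 (0.02 log units; within the scatter), with no change beyond the scatter expected. Compound 4 is estimated at 58000 nM, with a range of 28000 nM to 120000 nM.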

Compound 4, half-maximal inhibitory concentration: 64100 nM
Estimate against measurement, compound 4: 1.1-fold (0.04 log units) below; low and high end bracket the measured number.
By their numbers in this assay, from the lowest: compounds 2, 1, 3 and 4 (each within the scatter of the next).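

In this assay, 6-chloropyridin-2-yl in place of 2-chlorophenyl gives a 1.1-fold higher number from compound 3 to compound 4 (0.03 log units; within the scatter), so exchanging one aromatic ring for another on the amide-type nitrogen, with a ring nitrogen and a hydrogen-bond acceptor entering, brings no readable change. The new group also stands level with cyclopropyl and propyl, with a 1.5-fold higher number from compound 2 to compound 4 (0.17 log units; within the scatter) and a 1.3-fold higher number from compound 1 to compound 4 (0.13 log units; within the scatter). No other evidence bears on this result.

Going by these compounds, whether an amine, a carboxylic acid or a longer chain on this nitrogen would move the number beyond the scatter stays open. So does the effect of any change to the shared core.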